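A Furan-to-Thiophene Swap on a Shared Core

This account rests on a few compounds, and the source may have more. Where it says the series, first, only, none or still open, it means among the compounds named here.

The series rests on a shared core carrying a 3-hydroxyphenyl group and a 3-chlorophenyl group. Compound 1 `Oc1cccc(-c2cc(-c3ccncc3)nc(-c3cccc(Cl)c3)c2)c1` was entered in a functional assay on T47D cells (Homo sapiens) for cytotoxicity, read by CCK-8 assay and cell counting, with a stated time of 2 days (on this read-out lower numbers stand for stronger inhibition and higher numbers for weaker inhibition), but its result there stands as "not determined" (no result reported). For the measured compounds named here, compound 2 `Oc1cccc(-c2cc(-c3cccc(Cl)c3)nc(-c3ccco3)c2)c1` gives 3570 nM in this assay, which makes it the only numbered result so far, so no step between measured compounds can be read. Compound 3 `Oc1cccc(-c2cc(-c3ccsc3)nc(-c3cccc(Cl)c3)c2)c1` is the untested relative; it differs from compound 2 by thiophen-3-yl in place of furan-2-yl on an aromatic carbon. The leaving and entering groups match in heavy-atom count, ring size and count of hydrogen-bond acceptors, so the change from compound 2 to compound 3 in this assay is expected to be small, most likely within the scatter of repeated measurements and without a clear direction. On that basis compound 3 is expected to reach about 2800 nM, with a likely range from 1000 nM to 8000 nM. The expected step from compound 2 to compound 3 is a 1.3-fold lower number from compound 2 to compound 3 (0.11 log units; within the scatter).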

Compound 3, half-maximal inhibitory concentration: 3540 nM
Beside the measured number, compound 3's estimate is 1.3-fold (0.10 log units) below it; the measured number falls inside the stated range.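

For the compounds shown here, this is the first step that can be read at this position, on the aromatic carbon next to the ring nitrogen. In this assay, putting thiophen-3-yl in place of furan-2-yl gives a 1.0-fold lower number from compound 2 to compound 3 (0.00 log units; within the scatter), so these two five-membered aromatic rings cannot be told apart here, even though they differ in both hetero atom (sulfur against oxygen) and point of attachment. No measured evidence is at hand to explain this result.

Because the two changes come together, the compounds shown cannot say what each would do alone, and the steps to compound 1 cannot be read, as it has no number. From the compounds shown here alone, it also stays open whether an amine, a carboxylic acid or a longer chain at this position would move the number at all.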